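Fluoro in place of methyl, compound 1 to compound 4

The source may report more compounds than this note shows. Statements on the series, on what has been measured and on what is new or still open speak of the compounds shown alone.

Compound 1 `Cc1ccc(NC(=O)N[C@H](C)c2ccccc2)cc1` gives 64% in an ADME assay on the whole organism with Oryza sativa as the target, tested at 10 uM (a higher number here means a weaker effect of the compound at the concentration tested, a lower number a stronger effect), the lowest of the three numbers shown. Compound 2 `Cc1ccc(NC(=O)N[C@@H](C)c2ccccc2)cc1` gives 100% and compound 3 `COc1cccc(NC(=O)N[C@@H](C)c2ccccc2)c1` gives 99% in this assay. Going by the values given here, the only step between compounds that differ in one place is a number 36 percentage points higher from compound 1 to compound 2 (beyond the scatter), which rests on (the fact that compounds 1 and 2 differ only in the configuration as drawn). Compound 4 `C[C@@H](NC(=O)Nc1ccc(F)cc1)c1ccccc1` differs from compound 1 by fluoro in place of methyl on an aromatic carbon. No measured step changes this group, and compound 1 and compound 3 differ in more than one place, so nothing shown bears on the exchange itself. The expectation for compound 4 is therefore a step of no change at the digits printed from compound 1 to compound 4 (within the scatter), within the scatter. Compound 4 is estimated at 64% in this assay, with a range from 40% to 90%.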

Compound 4, a percentage reported as activity, at one concentration (the size of the read-out at that concentration, not a potency): 92%
For compound 4 the middle estimate is 28 percentage points below the measured one, and the stated range ends below it.
By their numbers in this assay, from the lowest: compound 1; then compounds 4, 3 and 2 (each within the scatter of the next).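

In this assay the group on this aromatic carbon, para to a large group, proves not to be interchangeable: with fluoro in place of methyl the number moves (a number 28 percentage points higher from compound 1 to compound 4 (beyond the scatter)). Going by these compounds alone, the lower number of compound 1 (64%) therefore depends on the methyl as well as on the configuration as drawn, and the earlier compounds showed only the latter (a number 36 percentage points higher from compound 1 to compound 2 (beyond the scatter)). Nothing at hand bears on why this exchange moves the number.

Open, from the compounds shown here alone, is whether chloro, ethyl or an amine at this place stays near compound 1 or near compound 4. Also open, going by these compounds, is whether the fluoro compound responds to the opposite configuration as the methyl pair does.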